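The source may report more compounds than this note shows. Statements on the series, on what has been measured and on what is new or still open speak of the compounds shown alone.

Compound 1 `CC1=C(C(=O)NC(C)C)C(c2ccco2)NC(=O)N1` sits lowest of the three numbers in an assay on membranes from CHO cells for displacement of a labelled ligand from adenosine receptor A1 (Homo sapiens), read by scintillation counting, with a stated time of 60 min, tested at 1 uM (on this read-out higher numbers stand for more inhibition at the one concentration tested (going by the name of the read-out) and lower numbers for less inhibition), giving 3%. Compound 2 `CC1=C(C(=O)NC(C)C)C(c2ccsc2)NC(=O)N1` gives 8%, and the step of a number 5 percentage points higher from compound 1 to compound 2 (within the scatter) stays within the scatter. Compound 3 `CC1=C(c2ncc(C)o2)C(c2ccco2)NC(=O)N1` gives 27%; the step of a number 24 percentage points higher from compound 1 to compound 3 (beyond the scatter) is a modest rise.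

Compound 4 `CC1=C(C(=O)OCC2CCC2)C(c2ccco2)NC(=O)N1` differs from compound 1 by cyclobutylmethoxy in place of isopropylamino on a carbonyl carbon. For the measured compounds named here, the one measured step at a related place is a number 24 percentage points higher from compound 1 to compound 3 (beyond the scatter), but there the whole isopropylcarbamoyl group was exchanged, whereas here the carbonyl carbon is kept and only its isopropylamino partner changes; no measured step covers an ester at this position. A small rise or no change beyond the scatter is therefore expected, a number 12 percentage points higher from compound 1 to compound 4 (beyond the scatter). For compound 4 the estimate in this assay is 15%, with a range from 2% to 40%.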

Compound 4, a percentage reported as inhibition, at one concentration (the size of the read-out at that concentration, not a potency): 42%
Compound 4: middle estimate off by 27 percentage points, on the low side, outside the stated range (above it).
By their numbers in this assay, from the lowest: compounds 1 and 2 (each within the scatter of the next); then compound 3; then compound 4.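

In this assay the carbonyl carbon on the double-bonded ring carbon can stay while its partner changes, and cyclobutylmethoxy in place of isopropylamino gives a number 39 percentage points higher from compound 1 to compound 4 (beyond the scatter) as a large step. The earlier change on this side of the core exchanged the whole isopropylcarbamoyl group and gave a number 24 percentage points higher from compound 1 to compound 3 (beyond the scatter) as a modest step. No measurement on hand accounts for the new step.

On these data alone, whether the ester oxygen or the cyclobutyl ring carries the step stays open; a methoxy or cyclobutylmethylamino partner on the same carbonyl would separate them. Also open, as far as these compounds go, is whether the step holds with thiophen-3-yl in place of furan-2-yl.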